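The source may report more compounds than this note shows. Statements on the series, on what has been measured and on what is new or still open speak of the compounds shown alone.

Compound 1, `O=C(N/N=C/c1ccc(F)cc1)Nc1ccc(Oc2ccnc3[nH]ccc23)c(F)c1`, gives 2330 nM in a functional assay on PC-3 cells (Homo sapiens) for antiproliferative activity, read by MTT assay, with a stated time of 72 h; on this read-out higher numbers stand for weaker inhibition and lower numbers for stronger inhibition.
Compound 2, `O=C(N/N=C/c1ccc(F)cc1)Nc1ccc(Oc2ccnc3[nH]ccc23)cc1`, gives 7490 nM in this assay.
Compound 3, `CN(C)CCn1cccc1/C=N/NC(=O)Nc1ccc(Oc2ccnc3[nH]ccc23)c(F)c1`, gives 1600 nM in this assay.

The three measured compounds share a core and differ at two ends. Compound 2 differs from compound 1 by hydrogen in place of fluoro on an aromatic carbon, and this change gave a 3.2-fold higher number from compound 1 to compound 2 (0.51 log units; beyond the scatter) in this assay. Compound 3 differs from compound 1 by 1-(2-(dimethylamino)ethyl)-1H-pyrrol-2-yl in place of 4-fluorophenyl on a carbon with a double bond to nitrogen, which gave a 1.5-fold lower number from compound 1 to compound 3 (0.16 log units; within the scatter), so the values of compound 1 and compound 3 cannot be told apart here. Compound 2 and compound 3 are not joined by a single change; their values are the widest apart among the three.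

Compound 4, `CN(C)CCn1cccc1/C=N/NC(=O)Nc1ccc(Oc2ccnc3[nH]ccc23)cc1`, has not been measured. It differs from compound 3 by hydrogen in place of fluoro on an aromatic carbon. This is the same change that leads from compound 1 to compound 2, made on the same place. Among the compounds with values here, only one example of it exists among the measured compounds, so its size on the core of compound 3 is not known from a second case.

Compound 4 is therefore expected to show a step of a 3.2-fold higher number from compound 3 to compound 4 (0.50 log units; beyond the scatter) in this assay, a size that rests on the single earlier case, because that change gave a 3.2-fold higher number from compound 1 to compound 2 (0.51 log units; beyond the scatter). The value of compound 4 is estimated at 5100 nM, with a likely range from 2500 nM to 12000 nM.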

Compound 4, half-maximal inhibitory concentration: 3930 nM
Estimate against measurement, compound 4: 1.3-fold (0.11 log units) above; low and high end bracket the measured number.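

Hydrogen in place of fluoro on the aromatic carbon gave a 2.5-fold higher number from compound 3 to compound 4 (0.39 log units; beyond the scatter) in this assay, and this step is of similar size on the two cores: the same change on two cores in this assay, a 3.2-fold higher number (0.51 log units; beyond the scatter) from compound 1 to compound 2 and a 2.5-fold higher number (0.39 log units; beyond the scatter) from compound 3 to compound 4, 1.3-fold (0.12 log units) apart, within the scatter of two such steps. Putting 1-(2-(dimethylamino)ethyl)-1H-pyrrol-2-yl in place of 4-fluorophenyl gave a 1.9-fold lower number from compound 2 to compound 4 (0.28 log units; within the scatter), and this exchange also agrees between its two cores, with neither step beyond the scatter: the same change on two cores in this assay, a 1.5-fold lower number (0.16 log units; within the scatter) from compound 1 to compound 3 and a 1.9-fold lower number (0.28 log units; within the scatter) from compound 2 to compound 4, 1.3-fold (0.12 log units) apart, within the scatter of two such steps. Together these results show that, in this set of four compounds, each change had much the same size whichever form the other end of the molecule took, but they do not show that either step would hold on any further core, since each comparison rests on a single pair of steps in one cell assay.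

The compounds shown leave open how chloro or methyl at the same place on the aromatic ring would compare with fluoro and hydrogen, and whether either would keep a step of this size on both cores. They also leave open what a morpholine in place of the dimethylamino group, or a longer chain such as 3-(dimethylamino)propyl in place of the 2-(dimethylamino)ethyl chain, would do to the values in this assay.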